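Fluoro on the fused ring: a small step from compound 1

The compounds below may be only part of what the source reports. "The series", "measured", "known", "first", "only" and "open" are said of these compounds alone.

The measured compounds, with their readings in an assay for inhibition of Alpha amylase (Homo sapiens), with a stated time of 10 min; on this read-out higher numbers stand for weaker inhibition and lower numbers for stronger inhibition:
compound 1 `COc1cc(Br)c(-c2nc3ccccc3[nH]2)cc1OC` gives 1510 nM
compound 2 `COc1ccc(-c2nc3cc(C)c(C)cc3[nH]2)c(OC)c1OC` gives 2300 nM
compound 3 `COc1cc(-c2nc3cc(C)c(C)cc3[nH]2)cc(OC)c1Br` gives 1590 nM

Among these three, compound 1 has the lowest number. Its nearest neighbour is compound 3, whose value lies within the scatter of that of compound 1; compound 2 stands furthest away, yet its value too is within the scatter of compound 1. None of the three can therefore be called stronger or weaker than another on this read-out.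

Compound 4 `COc1cc(Br)c(-c2nc3cc(F)ccc3[nH]2)cc1OC` has not yet been measured. It differs from compound 1 in a single place: fluoro in place of hydrogen on an aromatic carbon. The hydrogen that leaves sits on an aromatic carbon of a six-membered aromatic ring of carbon only, part of a fused system of two rings in the shared core, and a single fluorine atom takes its place, bringing no donor, no acceptor and no charge.

Within the data shown here, no pair of measured compounds differs by just such a change, so there is no measured step to lean on. Given that, compound 4 is expected to stay close to compound 1 in this assay, with a step of a 1.1-fold lower number from compound 1 to compound 4 (0.03 log units; within the scatter) that is estimated to be none beyond the scatter. Compound 4 is thus estimated at 1400 nM, most likely between 700 nM and 2800 nM.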

Compound 4, half-maximal inhibitory concentration: 1570 nM
For compound 4 the middle estimate is 1.1-fold (0.05 log units) below the measured one, within the range that was stated.
By their numbers in this assay, from the lowest: compounds 1, 4, 3 and 2 (each within the scatter of the next).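

Among these compounds, this is the first step in the set that changes one place only. In this assay, putting fluoro in place of hydrogen on an aromatic carbon gives a 1.0-fold higher number from compound 1 to compound 4 (0.02 log units; within the scatter) and so does not separate the two compounds. On this read-out, the six-membered aromatic ring of carbon only, at this carbon meta to a fused ring and para to a fused ring, therefore accepts a single fluorine atom with no change that can be read, and nothing available bears on the reason for this.

Going by these compounds, it remains open whether a larger or charged group on the same aromatic carbon, such as an amine, a carboxylic acid or a longer chain, would move the number beyond the scatter. Also open, on these data alone, is whether fluoro would read the same on the other aromatic carbons of this ring, or on the cores of compound 2 and compound 3, since this single step from compound 1 covers one place on one core.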